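A few compounds are considered here, and "the series" means these few. Any claim that something is new, unique, unknown or untested is made for them only; others in the source may bear on it.

Compound 1, `CN[C@@H]1CCN(c2cc3c(cc2F)c(=O)c(C(=O)O)cn3Cc2ccc(-c3ccccc3)cc2)C1`: 34800 nM. Compound 2, `CN[C@@H]1CCN(c2c(F)cc3c(=O)c(C(=O)O)cn(Cc4ccc(-c5ccccc5)cc4)c3c2OC)C1`: 57700 nM. Compound 3, `COc1c(N2CC[C@@H](CN)C2)c(F)cc2c(=O)c(C(N)=O)cn(Cc3ccc(-c4ccccc4)cc3)c12`: 184000 nM.

These three compounds were tested in an assay on isolated protein for inhibition of DNA topoisomerase 1 (Homo sapiens), with a stated time of 15 min; a higher number here means a weaker inhibitor, a lower number a stronger inhibitor. Compound 1 gives the lowest of the three numbers; compound 2 stands nearest, at a 1.7-fold higher number from compound 1 to compound 2 (0.22 log units; within the scatter), and compound 3 stands furthest.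

Compound 4, `CNCCCCNc1cc2c(cc1F)c(=O)c(C(=O)O)cn2Cc1ccc(-c2ccccc2)cc1`, has not yet been measured in this assay. It differs from compound 1 in one place: (4-(methylamino)butyl)amino in place of 3-(methylamino)pyrrolidin-1-yl on an aromatic carbon. Within the data shown here, the only measured step, a 1.7-fold higher number from compound 1 to compound 2 (0.22 log units; within the scatter), concerns a methoxy in place of hydrogen and does not bear on this exchange; no measured pair swaps a 3-(methylamino)pyrrolidin-1-yl for a (4-(methylamino)butyl)amino group. With nothing to lean on, the expected step from compound 1 to compound 4 is a 1.4-fold higher number from compound 1 to compound 4 (0.16 log units; within the scatter), not clearly beyond the scatter. Compound 4 is therefore estimated at 50000 nM, within 15000 nM to 170000 nM.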

Compound 4, half-maximal inhibitory concentration: 88300 nM
For compound 4 the middle estimate is 1.8-fold (0.25 log units) below the measured one; low and high end bracket the measured number.
By their numbers in this assay, from the lowest: compounds 1, 2 and 4 (each within the scatter of the next, the first and the last beyond it); then compound 3.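

Replacing 3-(methylamino)pyrrolidin-1-yl with the open-chain (4-(methylamino)butyl)amino on the aromatic carbon ortho to a fluoro group gives a 2.5-fold higher number from compound 1 to compound 4 (0.40 log units; beyond the scatter) in this assay. Among these compounds, this is the first measured change at this position, and it shows that the number responds modestly to the exchange, with the open chain giving the weaker result. No evidence at hand accounts for this step.

From the compounds shown here alone, it remains open whether a longer chain, a shorter chain or a piperazine at this position would shift the number in either direction. Going by these compounds, whether the step would hold in the methoxy-bearing core of compound 2 is also open.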